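Iodo in Place of Chloro: Expectation for Compound 3

A few compounds are considered here, and "the series" means these few. Any claim that something is new, unique, unknown or untested is made for them only; others in the source may bear on it.

Measured compounds in an assay on isolated protein for binding affinity to corticotropin-releasing factor receptor 1 (Homo sapiens); on this read-out lower numbers stand for stronger inhibition and higher numbers for weaker inhibition:
compound 1, `CCCN(CCC)c1cc(C)nc2c(-c3ncc(NC)cc3C)c(C)nn12`: 40 nM
compound 2, `CCCN(CCC)c1cc(C)nc2c(-c3ncc(Cl)cc3C)c(C)nn12`: 6.7 nM

Within the data shown here, compound 2 stands at the lower of the two numbers in this assay; its nearest neighbour is compound 1, and the single measured step, a 6.0-fold lower number from compound 1 to compound 2 (0.78 log units; beyond the scatter), is beyond the scatter. Compound 3, `CCCN(CCC)c1cc(C)nc2c(-c3ncc(I)cc3C)c(C)nn12`, differs from compound 2 in one place: iodo in place of chloro on an aromatic carbon.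

Among the measured compounds shown here, no measured step bears directly on this change. For the measured compounds named here, the only step in hand exchanges an amino-type group for a halogen, whereas the step from compound 2 to compound 3 exchanges one halogen for another, so that step offers no guide to direction or size here. With nothing in the data to suggest a move in either direction, the expected step is a 1.1-fold lower number from compound 2 to compound 3 (0.05 log units; within the scatter), within the usual scatter. In this assay compound 3 is therefore estimated at 6 nM, with a range from 2 nM to 20 nM that takes in the uncertainty of an unmeasured halogen swap.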

Compound 3, inhibition constant: 6.6 nM
Compound 3: middle estimate off by 1.1-fold (0.04 log units), on the low side, and the stated range covers the measured number.
By their numbers in this assay, from the lowest: compounds 3 and 2 (each within the scatter of the next); then compound 1.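

In this assay, the exchange on the 5-chloro-3-methylpyridin-2-yl group gives a 1.0-fold lower number from compound 2 to compound 3 (0.01 log units; within the scatter), so the read-out does not tell chloro and iodo apart at this position on an aromatic carbon, even though a single chlorine gives way to a single iodine. The comparison with methylamino now rests on two halogens rather than one: a 6.1-fold lower number from compound 1 to compound 3 (0.78 log units; beyond the scatter) stands beside a 6.0-fold lower number from compound 1 to compound 2 (0.78 log units; beyond the scatter), which shows that the lower number seen earlier is not confined to chloro, and no compound shown goes against this within the three groups compared. No available evidence bears on why chloro and iodo give matching results here.

On these data alone, whether this level result extends to the other halogens, fluoro and bromo, remains open, as does the outcome with groups such as methoxy, nitrile or a carboxylic acid at the same position. It is also open whether a tertiary amine such as dimethylamino would stay with methylamino or move towards the two halogens, since methylamino is the only amine shown at this position.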